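Shrinking the ring on the sulfonamide arm: compound 4

The compounds below may be only part of what the source reports. "The series", "measured", "known", "first", "only" and "open" are said of these compounds alone.

Three sulfonamide carboxamides sharing one core have been measured in an ADME assay on MDCKII-LE cells (Canis lupus familiaris) for permeability, read by transwell migration, in the apical to basolateral direction; a higher number here means that the compound crosses the layer faster, a lower number that the compound crosses the layer more slowly. Compound 1 `CC1(C)CO[C@@H]1CN([C@H](CCC(F)(F)F)C(N)=O)S(=O)(=O)c1ccc(Cl)cc1` gives 22.3 10^-6 cm/s, compound 2 `NC(=O)[C@@H](CCC(F)(F)F)N(C[C@@H]1CCCCO1)S(=O)(=O)c1ccc(Cl)cc1` gives 15.4 10^-6 cm/s, and compound 3 `NC(=O)[C@@H](CCC(F)(F)F)N(C[C@H]1CCCO1)S(=O)(=O)c1ccc(Cl)cc1` gives 19.1 10^-6 cm/s. Compound 2 sits close to its two neighbours: the move a 1.4-fold lower number from compound 1 to compound 2 (0.16 log units; within the scatter) and the move a 1.2-fold higher number from compound 2 to compound 3 (0.09 log units; within the scatter) both stay inside the usual scatter, as does a 1.2-fold lower number from compound 1 to compound 3 (0.07 log units; within the scatter), so the three numbers cannot be ranked.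

Compound 4 `NC(=O)[C@@H](CCC(F)(F)F)N(C[C@H]1CCO1)S(=O)(=O)c1ccc(Cl)cc1` has not yet been measured. The change from compound 2 is oxetan-2-yl in place of oxan-2-yl on a saturated chain carbon bound to a sulfonamide nitrogen. Within the data shown here, the steps that bear on it are the swaps among ring sizes on this same position, a 1.4-fold lower number from compound 1 to compound 2 (0.16 log units; within the scatter) and a 1.2-fold higher number from compound 2 to compound 3 (0.09 log units; within the scatter), neither of which left the scatter. On that basis no change beyond the scatter is expected in this assay, with at most a slight rise.

Compound 4 is therefore estimated at 18 10^-6 cm/s, with a likely range from 11 10^-6 cm/s to 29 10^-6 cm/s, which would mean the expected step of a 1.2-fold higher number from compound 2 to compound 4 (0.07 log units; within the scatter).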

Compound 4, apparent permeability: 28.7 10^-6 cm/s
For compound 4 the middle estimate is 1.6-fold (0.20 log units) below the measured one; the range from low to high includes it.
By their numbers in this assay, from the lowest: compounds 2, 3, 1 and 4 (each within the scatter of the next).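

On a saturated chain carbon bound to a sulfonamide nitrogen, the oxetan-2-yl group adds a four-membered ring to the series in this assay, and each of its steps stays within the scatter (a 1.9-fold higher number from compound 2 to compound 4 (0.27 log units; within the scatter); a 1.5-fold higher number from compound 3 to compound 4 (0.18 log units; within the scatter); a 1.3-fold higher number from compound 1 to compound 4 (0.11 log units; within the scatter)). Even the step from oxan-2-yl, the largest of these, does not leave the scatter. Across the four-, five- and six-membered rings, and with or without the dimethyl substitution of 3,3-dimethyloxetan-2-yl, the four compounds therefore still cannot be ranked.

Going by these compounds, it remains open whether an amine, a carboxylic acid or an open-chain ether in this place would move apparent permeability beyond the scatter. The data shown offer no explanation for these numbers.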